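A Sulfur Ring Replaces a Triazole on the Core

The source may hold more compounds than are shown below. What is called first, only, known or untested is meant among the compounds shown, and "the series" means these compounds.

Compound 2 `CCC(C)(C)Cc1c[nH]c(CCc2ccc(-n3ccnn3)cc2)n1` gives 57 nM in a functional assay on HEK293 cells for agonist activity at Bombesin receptor subtype-3 (Mus musculus), read by luminescence and calcium flux, with a stated time of 10 min (on this read-out higher numbers stand for an effect only at larger amounts of compound and lower numbers for an effect already at smaller amounts), the highest of the three numbers recorded. Compound 1 `CCC(C)(C)Cc1c[nH]c(CCc2ccc(-c3cccc(C)n3)cc2)n1` gives 19 nM and compound 3 `CCC(C)(C)Cc1c[nH]c(CCc2ccc(-c3cccc(N)n3)cc2)n1` gives 3.9 nM; the step of a 3.0-fold higher number from compound 1 to compound 2 (0.48 log units; beyond the scatter) and the step of a 15-fold lower number from compound 2 to compound 3 (1.16 log units; beyond the scatter) place compound 2 furthest from compound 3, with compound 1 nearer. Compound 4 `CCC(C)(C)Cc1c[nH]c(CCc2ccc(-c3csnn3)cc2)n1` differs from compound 2 by 1,2,3-thiadiazol-4-yl in place of 1H-1,2,3-triazol-1-yl on an aromatic carbon. Within the data shown here, no measured step swaps one five-membered ring for another; the steps of a 3.0-fold higher number from compound 1 to compound 2 (0.48 log units; beyond the scatter) and a 4.9-fold lower number from compound 1 to compound 3 (0.69 log units; beyond the scatter) concern a six-membered ring and a substituent on it. Among the measured compounds shown here, with no direct precedent, the step expected is a 1.4-fold lower number from compound 2 to compound 4 (0.15 log units; within the scatter), within the scatter. Compound 4 is therefore estimated at 40 nM in this assay, between 12 nM and 130 nM.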

Compound 4, half-maximal effective concentration: 11 nM
Beside the measured number, compound 4's estimate is 3.6-fold (0.56 log units) above it; measured number below the stated range.
By their numbers in this assay, from the lowest: compound 3; then compounds 4 and 1 (each within the scatter of the next); then compound 2.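

Swapping one five-membered ring for another at this place, on the six-membered aromatic ring of carbon only, keeps the heavy-atom and acceptor counts yet gives a 5.2-fold lower number from compound 2 to compound 4 (0.71 log units; beyond the scatter), so ring size alone does not set the number here. A five-membered ring can also match a six-membered one: a 1.7-fold lower number from compound 1 to compound 4 (0.24 log units; within the scatter). The 6-aminopyridin-2-yl group still keeps its edge, with a 2.8-fold higher number from compound 3 to compound 4 (0.45 log units; beyond the scatter).

Nothing shown here explains the difference between the two five-membered rings. From the compounds shown here alone, whether a thiophene or furan ring here would fall nearer compound 4 or compound 2 remains open.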